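Thioether chalcone analogues: hydroxy-nitro phenyl variant on DU-145

This account rests on a few compounds, and the source may have more. Where it says the series, first, only, none or still open, it means among the compounds named here.

Measured compounds:
compound 1 `COc1ccc(/C=C(/SCc2ccc(Cl)cc2)C(=O)c2ccc(Cl)cc2)cc1`: 10000 nM
compound 2 `O=C(/C(=C\c1ccc(O)cc1O)SCc1ccc(Cl)cc1)c1ccc(Cl)cc1`: 50000 nM
compound 3 `O=C(/C(=C\c1c(O)cc(O)cc1O)SCc1ccc(Cl)cc1)c1ccc(Cl)cc1`: > 100000 nM

In a functional assay on DU-145 cells (Homo sapiens) for inhibition, read by trypan blue exclusion, with a stated time of 96 h (on this read-out lower numbers stand for stronger inhibition of growth and higher numbers for weaker inhibition of growth), compound 1 gives 10000 nM. Compound 2 carries a 2,4-dihydroxyphenyl in place of the 4-methoxyphenyl, and the step is a 5.0-fold higher number from compound 1 to compound 2 (0.70 log units; beyond the scatter). For compound 3 this assay reports only a limit, > 100000 nM, so its place among the three is known only as an edge (the limit of > 100000 nM in this assay, at which 1 of the 3 values shown sits). The steps to it are an at least 10-fold higher number from compound 1 to compound 3 (1.00 log units; beyond the scatter) and an at least 2.0-fold higher number from compound 2 to compound 3 (0.30 log units; that floor lies within the scatter).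

Compound 4 `O=C(/C(=C\c1ccc(O)c([N+](=O)[O-])c1)SCc1ccc(Cl)cc1)c1ccc(Cl)cc1` differs from compound 3 by 4-hydroxy-3-nitrophenyl in place of 2,4,6-trihydroxyphenyl on a double-bonded chain carbon bound to a double-bonded chain carbon. Going by the values given here, the measured steps show that adding hydroxy groups to this aryl ring gave higher numbers; compound 4 keeps one hydroxy and adds a nitro group, which has no precedent here. The expectation is a lower number than the limit of compound 3, a step of an at least 3.3-fold lower number from compound 3 to compound 4 (0.52 log units; beyond the scatter), landing near compounds 1 and 2. Compound 4 is thus estimated at 30000 nM, within 10000 nM to 100000 nM.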

Compound 4, concentration for 50% growth inhibition: 10000 nM
Compound 4: middle estimate off by 3.0-fold (0.48 log units), on the high side; the range from low to high includes it.
By their numbers in this assay, from the lowest: compounds 1 and 4 (each within the scatter of the next); then compound 2. At a limit, above all of these: compound 3.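

In this assay, the place on a double-bonded chain carbon bound to a double-bonded chain carbon accepts a 4-hydroxy-3-nitrophenyl that still carries a hydroxy, and the change from 2,4-dihydroxyphenyl gives a 5.0-fold lower number from compound 2 to compound 4 (0.70 log units; beyond the scatter). A hydroxy on this aryl group therefore does not by itself go with a higher number, and replacing the 4-methoxyphenyl gives no change at the digits printed from compound 1 to compound 4 (within the scatter), so the rise seen earlier does not follow every replacement of that group. The change from 2,4,6-trihydroxyphenyl gives an at least 10-fold lower number from compound 3 to compound 4 (1.00 log units; beyond the scatter), and that size is only a floor: the limit of > 100000 nM in this assay, at which 1 of the 4 values shown sits.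

The compounds shown leave open whether the nitro group alone separates compound 4 from compound 2, as that change also removes a hydroxy. Going by these compounds, whether an amine or a carboxylic acid in the nitro group's place would match compound 4 also stays open.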